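A few compounds are considered here, and "the series" means these few. Any claim that something is new, unique, unknown or untested is made for them only; others in the source may bear on it.

In an ADME assay on Vero cells (Chlorocebus sabaeus) for cytotoxicity, read by MTT assay, with a stated time of 48 h (on this read-out higher numbers stand for weaker inhibition and lower numbers for stronger inhibition), two compounds sharing one core have been tested so far. Compound 1 `Cc1cccc(C(=O)OC2CCC(CN3CCN(c4cc(=O)c5cc(C(F)(F)F)cc([N+](=O)[O-])c5s4)CC3)CC2)c1` gives > 64 ug/mL as its result, which is a limit of the assay and not a number. Compound 2 `O=C(OC1CCC(CN2CCN(c3cc(=O)c4cc(C(F)(F)F)cc([N+](=O)[O-])c4s3)CC2)CC1)C1CCCCC1` gives > 64 ug/mL as its result, again only a limit, so its place can be stated no more exactly than that. In short, the limit of > 64 ug/mL in this assay, at which 2 of the 2 values shown sit, and no exact number is yet available. Compound 3 `CC(=O)NC1CCC(CN2CCN(c3cc(=O)c4cc(C(F)(F)F)cc([N+](=O)[O-])c4s3)CC2)CC1` has not yet been measured. On a saturated ring carbon, it carries acetamido in place of (cyclohexylcarbonyl)oxy on a saturated ring carbon as its difference from compound 2. Among the measured compounds shown here, the one measured step that bears on this is a step that the two limits leave unreadable from compound 1 to compound 2 and its size cannot be read. It therefore offers no size to carry over, and no step beyond the usual scatter is expected in this assay on this thin basis. The expected change is a step that the limit leaves unreadable from compound 2 to compound 3 and it remains a rough estimate. The estimated value for compound 3 is 70 ug/mL with an expected range from 25 ug/mL to 200 ug/mL as its span.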

Compound 3, half-maximal inhibitory concentration: > 64 ug/mL
Compound 3: a limit, no number (the forecaster's own chance of this, stated with the estimate: 75%); the middle value does not contradict the limit.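

In this assay, compound 3 gives a limit and not a number, as do compound 1 and compound 2, so no step among these three compounds can be read. All three share one result: the limit of > 64 ug/mL in this assay, at which 3 of the 3 values shown sit.

On these data alone, what stays open is whether the different groups on the saturated ring carbon change this read-out at all, and what exact number each compound would give.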